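A few compounds are considered here, and "the series" means these few. Any claim that something is new, unique, unknown or untested is made for them only; others in the source may bear on it.

Compound 2 `COC(=O)c1cc(N)c(Nc2ccc(C#N)cc2)cc1Oc1c(C)cc(/C=C/C#N)cc1C` and compound 1 `CCNC(=O)c1cc(N)c(Nc2ccc(C#N)cc2)cc1Oc1c(C)cc(/C=C/C#N)cc1C` share one core and differ only at the carbonyl group. In a physicochemical assay for solubility, read by HPLC, in phosphate buffer, with a stated time of 4 h, at pH 7.4 (a higher number here means a more soluble compound, a lower number a less soluble compound), compound 2 gives 1.21 ug/mL, and compound 1 gives 1.08 ug/mL. The step of a 1.1-fold higher number from compound 1 to compound 2 (0.05 log units; within the scatter) does not separate the two; the numbers of compound 2 and compound 1 sit within the scatter of each other, so compound 2 cannot be said to stand apart from compound 1 on this pair of values.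

Compound 3 `Cc1cc(/C=C/C#N)cc(C)c1Oc1cc(Nc2ccc(C#N)cc2)c(N)cc1C(=O)OCCC#N` is not yet measured. It differs from compound 2 by cyanomethyl in place of hydrogen on a saturated chain carbon bound to an oxygen next to a carbonyl group. Within the data shown here, the only measured step, the one from compound 1 to compound 2, touches the same carbonyl group but swaps one group for another rather than extending the ester chain, and it stayed within the scatter; no measured step follows a methoxycarbonyl to a (2-cyanoethoxy)carbonyl. With nothing to point either way, compound 3 is expected to show a step of a 1.1-fold higher number from compound 2 to compound 3 (0.03 log units; within the scatter) that stays within the scatter in this assay. Compound 3 is therefore estimated at 1.3 ug/mL, with a range from 0.5 ug/mL to 3.5 ug/mL.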

Compound 3, solubility: 0.36 ug/mL
Beside the measured number, compound 3's estimate is 3.6-fold (0.56 log units) above it; the whole stated range lies above it.
By their numbers in this assay, from the lowest: compound 3; then compounds 1 and 2 (each within the scatter of the next).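

In this assay, among these compounds, the carbonyl substituent turns out to be able to shift the number: the earlier swap of ethylamino for methoxy stayed within the scatter, whereas cyanomethyl in place of hydrogen on a saturated chain carbon bound to an oxygen next to a carbonyl group gives a 3.4-fold lower number from compound 2 to compound 3 (0.53 log units; beyond the scatter) and is the first step here beyond it. The same holds against the amide, where the comparison gives a 3.0-fold lower number from compound 1 to compound 3 (0.48 log units; beyond the scatter) and so sets compound 3 apart from compound 1 and compound 2, which remain within the scatter of each other. No measurement at hand explains this difference, and the numbers alone cannot assign it to the nitrile or to the longer chain.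

The compounds shown leave open whether a plain ethyl or propyl ester would read with compound 3 or with compound 2, which would separate the nitrile from the added length. They also leave open how an amine or a carboxylic acid at the end of the same chain would read in this assay as well as whether a nitrile added to the ethylamino chain of compound 1 would give a step of like size.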